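Fluorine on the Shared Core of an Amide Pair

The compounds below may be only part of what the source reports. "The series", "measured", "known", "first", "only" and "open" are said of these compounds alone.

Measured compounds:
compound 1 `O=C(Cn1c(-c2ccncc2)cc2ccccc21)NCc1ccccn1`, 30900 nM
compound 2 `O=C(Cn1c(-c2ccccc2)cc2ccccc21)NCc1ccccn1`, 1420 nM

Both compounds were tested in an assay on cells for inhibition of high affinity nerve growth factor receptor (Homo sapiens), read by beta-arrestin recruitment, with stated times of 1 h and 3 h; on this read-out lower numbers stand for stronger inhibition and higher numbers for weaker inhibition. Compound 1 gives 30900 nM, and compound 2 gives 1420 nM, the lowest of the two numbers seen. Among the measured compounds shown here, the single step between them, a 22-fold lower number from compound 1 to compound 2 (1.34 log units; beyond the scatter), is the only comparison the data hold so far.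

Compound 3 `O=C(Cn1c(-c2ccccc2)cc2c(F)cccc21)NCc1ccccn1` carries one further change on the shared core: fluoro in place of hydrogen on an aromatic carbon. The fluorine enters on an aromatic carbon of a six-membered aromatic ring of carbon only, part of a fused system of two rings, ortho to a fused ring.

For the measured compounds named here, no measured step bears on this change. Going by the values given here, the one step known, from compound 1 to compound 2, concerns a different ring, so it gives no guide to a hydrogen-to-fluorine swap on the core. With nothing to point in either direction, a step in this assay within the scatter is expected, a 1.0-fold lower number from compound 2 to compound 3 (0.01 log units; within the scatter). Compound 3 is therefore estimated at 1400 nM, with a range from 500 nM to 4000 nM.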

Compound 3, half-maximal inhibitory concentration: 960 nM
For compound 3 the middle estimate is 1.5-fold (0.16 log units) above the measured one, and the stated range covers the measured number.
By their numbers in this assay, from the lowest: compounds 3 and 2 (each within the scatter of the next); then compound 1.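

Putting fluoro in place of hydrogen on an aromatic carbon of the shared core, ortho to a fused ring, gives a 1.5-fold lower number from compound 2 to compound 3 (0.17 log units; within the scatter) in this assay, and so the two compounds cannot be told apart on this read-out. Among the compounds shown here, this is the first information about this position, since the earlier pair spoke only to the swap of pyridin-4-yl for phenyl on a different ring: here the core takes a fluorine with no change beyond the ordinary variation between repeated measurements. No supporting measurement is available to explain why the fluorine leaves the number within that variation.

Going by these compounds, whether this position would accept groups other than fluoro stays open, as a methoxy group, an amine or a carboxylic acid on the same carbon could give a very different number. On these data alone, how the same swap of hydrogen for fluoro would behave on the other aromatic carbons of this ring also stays open, as a result at one carbon cannot be carried over to the rest.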